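The source may report more compounds than this note shows. Statements on the series, on what has been measured and on what is new or still open speak of the compounds shown alone.

In a functional assay on PANC-1 cells (Homo sapiens) for cytotoxicity, read by MTT assay, with a stated time of 72 h (a lower number here means a stronger inhibitor, a higher number a weaker inhibitor), compound 1 `O=C1C(Nc2ccc(OC(F)(F)F)cc2)=CC(=O)c2ncncc21` gives 900 nM. This stands level with compound 2 `O=C1C(NCc2ccc(F)cc2)=CC(=O)c2ncncc21` at 1000 nM, as the two values lie within the scatter of each other. Compound 3 `O=C1C(Nc2cccc(B(O)O)c2)=CC(=O)c2ncncc21` gives a clearly higher 9000 nM. Compound 4 `COc1ccc(NC2=CC(=O)c3ncncc3C2=O)cc1` has not yet been measured. It departs from compound 1 by methyl in place of trifluoromethyl on an oxygen on an aromatic ring, trifluoromethoxy to methoxy: methyl in place of trifluoromethyl on an oxygen on an aromatic ring. For the measured compounds named here, no measured pair isolates this change, so in this assay no step beyond the scatter is expected, with the number perhaps slightly higher. The expected step is a 1.7-fold higher number from compound 1 to compound 4 (0.22 log units; within the scatter). For compound 4 the estimate is 1500 nM, with an expected range of 500 nM to 5000 nM.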

Compound 4, half-maximal inhibitory concentration: 800 nM
Estimate against measurement, compound 4: 1.9-fold (0.27 log units) above, and the stated range covers the measured number.
By their numbers in this assay, from the lowest: compounds 4, 1 and 2 (each within the scatter of the next); then compound 3.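

Methyl in place of trifluoromethyl on an oxygen on an aromatic ring gives, in this assay, a 1.1-fold lower number from compound 1 to compound 4 (0.05 log units; within the scatter), the first comparison here that differs in one place. At this oxygen, trifluoromethoxy and methoxy therefore cannot be told apart in this assay, even though three fluorine atoms leave with the change. Nothing available accounts for this result. Still open, from the compounds shown here alone, is whether the number holds with an ethyl group or a longer chain on the same oxygen. Equally open, going by these compounds, is what an amine or a carboxylic acid would give in place of the whole ether group.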